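Chloro for methoxy beside the ring nitrogen of a urea

The compounds below may be only part of what the source reports. "The series", "measured", "known", "first", "only" and "open" are said of these compounds alone.

compound 1: `CSc1cc(C)nc(SC)c1NC(=O)N(Cc1cccc(Oc2ccc(Br)cc2)c1)C1CCCCCC1`, 73 nM
compound 2: `COc1cc(C)nc(OC)c1NC(=O)N(Cc1ccc(Oc2ccc(F)cc2)cc1)C1CCCCCC1`, 33 nM
compound 3: `COc1nc(C)cc(SC)c1NC(=O)N(Cc1ccc(Oc2ccc(F)cc2)cc1)C1CCCCCC1`, 29 nM

In an assay for inhibition of acyl-CoA:cholesterol acyltransferase (Oryctolagus cuniculus), using microsomes (on this read-out higher numbers stand for weaker inhibition and lower numbers for stronger inhibition), compound 3 gives 29 nM, the lowest of the three numbers. Its nearest neighbour is compound 2, and the pair of values sits within the scatter; the furthest is compound 1, whose number lies beyond the scatter above that of compound 3. Among the measured compounds shown here, the one single-point step that is measured, a 1.1-fold lower number from compound 2 to compound 3 (0.06 log units; within the scatter), exchanges methoxy for methylsulfanyl and stays within the scatter.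

Compound 4, `CSc1cc(C)nc(Cl)c1NC(=O)N(Cc1ccc(Oc2ccc(F)cc2)cc1)C1CCCCCC1`, differs from compound 3 by chloro in place of methoxy on an aromatic carbon. For the measured compounds named here, no measured step exchanges methoxy for chloro at this position, so the only guidance is the neighbouring exchange of methoxy for methylsulfanyl, which moved the number little. Compound 4 is therefore expected to show a step of a 1.2-fold higher number from compound 3 to compound 4 (0.08 log units; within the scatter), without a shift beyond the scatter. The estimate for compound 4 in this assay is 35 nM, with a range from 12 nM to 100 nM.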

Compound 4, half-maximal inhibitory concentration: 46 nM
Estimate against measurement, compound 4: 1.3-fold (0.12 log units) below; low and high end bracket the measured number.
By their numbers in this assay, from the lowest: compounds 3, 2, 4 and 1 (each within the scatter of the next, the first and the last beyond it).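

In this assay the exchange of methoxy for chloro at this place, next to the ring nitrogen, gives a 1.6-fold higher number from compound 3 to compound 4 (0.20 log units; within the scatter). Among the compounds shown here, this is the first reading of a change at this place, and it shows that chloro can stand in place of methoxy without a shift beyond the scatter. The hydrogen-bond acceptor counted in the methoxy group can thus leave this place, in this pair, with the number staying within the scatter, but nothing available accounts for the size of the step. The step of a 1.4-fold higher number from compound 2 to compound 4 (0.14 log units; within the scatter) cannot be read for this position, since the two compounds differ in more than one place on the group carried by the amide-type nitrogen.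

The compounds shown leave open how an amine or a longer chain such as ethoxy would fare at this place. For the compounds shown here, they also leave open whether the chloro exchange would hold with a different group on the other side of the urea, such as the one in compound 1.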